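The source may report more compounds than this note shows. Statements on the series, on what has been measured and on what is new or still open speak of the compounds shown alone.

Compound 1 `CCCCc1nc(Cl)c(CO)n1CCCOc1cc2c(Nc3ccc(OC)cc3)ncnc2cc1OC`: 20000 nM
Compound 2 `CCCCc1nc(Cl)c(CO)n1CCCOc1cc2c(Nc3cccc(Br)c3)ncnc2cc1OC`: 8200 nM

Both compounds were measured in a functional assay on MCF7 cells (Homo sapiens) for cytotoxicity, read by MTT assay, with a stated time of 24 h (on this read-out higher numbers stand for weaker inhibition and lower numbers for stronger inhibition), which reports how much compound is needed to reach the stated inhibition of the growth signal of the cells. For the measured compounds named here, compound 2 stands at the lower of the two numbers, its only neighbour being compound 1, which sits higher by the one measured step, a 2.4-fold lower number from compound 1 to compound 2 (0.39 log units; beyond the scatter); that step swaps the whole ring that hangs from the nitrogen, 3-bromophenyl in place of 4-methoxyphenyl. Compound 3 `C#Cc1cccc(Nc2ncnc3cc(OC)c(OCCCn4c(CCCC)nc(Cl)c4CO)cc23)c1` keeps that ring and changes only its substituent: ethynyl in place of bromo on an aromatic carbon. Going by the values given here, no measured step alters this group alone, so the one step on record bears only loosely, by showing that changes on this ring move the number modestly. The expected change, a 1.4-fold lower number from compound 2 to compound 3 (0.14 log units; within the scatter), is therefore small and may fall within the scatter. Compound 3 is estimated at 6000 nM, ranging from 2500 nM to 15000 nM.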

Compound 3, half-maximal inhibitory concentration: 10000 nM
Estimate against measurement, compound 3: 1.7-fold (0.22 log units) below; the measured number falls inside the stated range.
By their numbers in this assay, from the lowest: compounds 2, 3 and 1 (each within the scatter of the next, the first and the last beyond it).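

At this ring position, swapping bromo for ethynyl leaves the number unchanged within the usual scatter of this assay, with a 1.2-fold higher number from compound 2 to compound 3 (0.09 log units; within the scatter) as the step, so a single bromine atom and a two-carbon group with a triple bond cannot be told apart here. The earlier step from the 4-methoxyphenyl ring to the 3-bromophenyl ring lay beyond the scatter, but the new step of a 2.0-fold lower number from compound 1 to compound 3 (0.30 log units; within the scatter) lies within it, so that separation is not clearly repeated with 3-ethynylphenyl. No evidence is available on what lies behind these readings.

From the compounds shown here alone, whether an amine or a carboxylic acid at this ring position would shift the number remains open. So does the effect of a longer chain ending in the triple bond, or of changes elsewhere on the shared core.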